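The source may hold more compounds than are shown below. What is called first, only, known or untested is meant among the compounds shown, and "the series" means these compounds.

Measured so far in an assay on CHO cells for displacement of a labelled ligand from prostaglandin D2 receptor 2 (Homo sapiens), read by scintillation counting; a lower number here means a stronger inhibitor, a higher number a weaker inhibitor:
compound 1 `CCCS(=O)(=O)c1cc(C#Cc2cc(Cl)ccc2OCC(=O)O)c(C)cc1NC(C)=O`, 1.3 nM
compound 2 `COCCNS(=O)(=O)c1ccc(C)c(C#Cc2cc(Cl)ccc2OCC(=O)O)c1`, 3.6 nM
compound 3 `O=C(O)COc1ccc(Cl)cc1C#Cc1cccc(C(F)(F)F)c1`, 92 nM

Compound 2 stands second highest of the three numbers in this assay, with compound 1 nearest and compound 3 furthest away; both gaps lie beyond the scatter. Compound 4 `Cc1ccc(S(=O)(=O)CC(C)C)cc1C#Cc1cc(Cl)ccc1OCC(=O)O` is not yet measured. It differs from compound 2 in one place: isobutyl in place of (2-methoxyethyl)amino on a sulfonyl sulfur. Compound 1 also carries an alkyl group on the sulfonyl sulfur and gives 1.3 nM, so compound 4 is expected to land near compound 2, if anything at a somewhat lower number, with the step from compound 2 estimated at a 1.4-fold lower number from compound 2 to compound 4 (0.16 log units; within the scatter), not clearly beyond the scatter. Compound 4 is therefore estimated at 2.5 nM, within 0.8 nM to 8 nM.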

Compound 4, inhibition constant: 3 nM
Compound 4: the middle estimate sits 1.2-fold (0.08 log units) below what was measured; the range from low to high includes it.
By their numbers in this assay, from the lowest: compound 1; then compounds 4 and 2 (each within the scatter of the next); then compound 3.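

In this assay, isobutyl in place of (2-methoxyethyl)amino on a sulfonyl sulfur gives a 1.2-fold lower number from compound 2 to compound 4 (0.08 log units; within the scatter). At this position, then, the nitrogen, the oxygen and the hydrogen-bond donor and acceptor of (2-methoxyethyl)amino are not required for a number in this range, since an all-carbon group with neither donor nor acceptor cannot be told apart from it. No measured evidence bears on why the two groups match.

Open, from the compounds shown here alone, is whether a carboxylic acid, an amine or a longer chain on this sulfonyl sulfur would stay in the same range.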